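This account rests on a few compounds, and the source may have more. Where it says the series, first, only, none or still open, it means among the compounds named here.

Compound 1 `COc1ccc(Nc2c(-c3ccc(C)c(C)c3)c(C)nn2-c2ccccc2C)c(C(=O)O)c1`, in a functional assay for antagonist activity at adenosine receptor A1 (Homo sapiens), read by cAMP accumulation (a lower number here means a stronger inhibitor, a higher number a weaker inhibitor), compound 1 gives 568 nM.
Compound 2 `COc1ccc(Nc2c(-c3ccc(F)cc3)c(C)nn2-c2ccccc2C)c(C(=O)O)c1`, in this assay compound 2 gives 1.39 nM.

Going by the values given here, of the two compounds measured so far, compound 2 gives the lower number, and its distance from compound 1 is large: a 410-fold lower number from compound 1 to compound 2 (2.61 log units; beyond the scatter). Compound 3 `COc1ccc(Nc2c(-c3ccc(F)c(F)c3)c(C)nn2-c2ccccc2C)c(C(=O)O)c1` is the unmeasured compound that follows from compound 2 by a single change: fluoro in place of hydrogen on an aromatic carbon. Among the compounds with values here, only one measured step bears on this change, the step from compound 1 to compound 2, in which the ring that carries the new fluoro lost two methyl groups and gained one fluoro, with the large drop already named. That step shows how strongly this ring responds to what sits on it, but it does not show what a second fluoro does. Compound 1 carried methyls at that spot rather than fluoro. A small second substituent at the position where compound 1 held a methyl is therefore expected to move the number only modestly, if at all, and more likely upward than downward. For compound 3 the expected step is a 1.8-fold higher number from compound 2 to compound 3 (0.25 log units; within the scatter). Compound 3 is thus estimated at 2.5 nM, within a range from 0.6 nM to 12 nM.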

Compound 3, half-maximal inhibitory concentration: 294 nM
For compound 3 the middle estimate is 120-fold (2.07 log units) below the measured one, outside the stated range (above it).
By their numbers in this assay, from the lowest: compound 2; then compounds 3 and 1 (each within the scatter of the next).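

The extra fluoro is one heavy atom, yet it takes the number back up (a 210-fold higher number from compound 2 to compound 3 (2.33 log units; beyond the scatter)) in this assay, so the carbon ortho to the fluoro group is highly sensitive to what sits on it, at least in these compounds. The other new step (a 1.9-fold lower number from compound 1 to compound 3 (0.29 log units; within the scatter)) lies within the scatter, so the 3,4-difluorophenyl and 3,4-dimethylphenyl compounds cannot be told apart here, and keeping the fluoro of compound 2 does not by itself preserve its low number. Among these three compounds, the low number therefore appears only with the 4-fluorophenyl group, where that carbon bears hydrogen and not fluoro or methyl, but no data shown here give a reason for so large an effect from so small a change.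

Going by these compounds, what remains open is whether any group other than hydrogen can be placed on that carbon without the same loss, for example a hydroxyl, an amine or a methoxy group. It is also unclear whether fluoro at that carbon would have the same effect with a methyl group in place of the fluoro of compound 2, or on a phenyl ring with no other substituent.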